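Clearance of a Sulfonyl Aryl Series: Removing Two Chlorines

A few compounds are considered here, and "the series" means these few. Any claim that something is new, unique, unknown or untested is made for them only; others in the source may bear on it.

Measured compounds:
Compound 1, `O=S(=O)(c1ccc(F)c(Cl)c1)c1cnc2c(F)cccc2c1-c1cccc(Cl)c1`, 0.18 mL/min
Compound 2, `O=S(=O)(c1cc(Cl)cc(Cl)c1)c1cnc2c(F)cccc2c1-c1cccc(Cl)c1`, 1.2 mL/min

These two compounds share a core and differ only in the ring attached to the sulfonyl sulfur. In an ADME assay on microsomes from liver (Homo sapiens) for metabolic stability, tested at 2.5 uM (on this read-out lower numbers stand for slow clearance and higher numbers for fast clearance), compound 2 gives 1.2 mL/min, the higher of the two numbers; compound 1, the nearest comparison, gives 0.18 mL/min. Going by the values given here, the single measured step, a 6.7-fold higher number from compound 1 to compound 2 (0.82 log units; beyond the scatter), shows that exchanging the ring on the sulfonyl sulfur can shift clearance well beyond the scatter.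

Compound 3, `O=S(=O)(c1cccc(F)c1)c1cnc2c(F)cccc2c1-c1cccc(Cl)c1`, has not yet been measured in this assay. It differs from compound 2 in one place: 3-fluorophenyl in place of 3,5-dichlorophenyl on a sulfonyl sulfur. This change runs roughly opposite to the measured step: where the step from compound 1 to compound 2 added a chlorine and removed a fluorine and raised clearance, the step to compound 3 removes both chlorines and keeps a single fluorine. A step downward in this assay, of a size comparable to a 6.7-fold higher number from compound 1 to compound 2 (0.82 log units; beyond the scatter), is therefore expected, as an 8.0-fold lower number from compound 2 to compound 3 (0.90 log units; beyond the scatter). Compound 3 is estimated at 0.15 mL/min, within 0.05 mL/min to 0.5 mL/min.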

Compound 3, intrinsic clearance in a liver preparation (reported as CLH), per the amount of preparation that the assay uses: 0.56 mL/min
Compound 3: the middle estimate sits 3.7-fold (0.57 log units) below what was measured; measured number above the stated range.
By their numbers in this assay, from the lowest: compound 1; then compound 3; then compound 2.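

In this assay, 3-fluorophenyl in place of 3,5-dichlorophenyl on a sulfonyl sulfur gives a 2.1-fold lower number from compound 2 to compound 3 (0.33 log units; beyond the scatter) and shows that clearance can fall when both chlorines leave this ring, though the fall is only partial. Set against 3-chloro-4-fluorophenyl, the same ring gives a 3.1-fold higher number from compound 1 to compound 3 (0.49 log units; beyond the scatter) and leaves compound 1, which keeps a chlorine on this ring, the lowest of the three, so taking chlorine away does not by itself lead to the lowest number, and compound 1 goes against any simple rule that less chlorine on this ring means slower clearance. Nothing available explains why these three rings fall in this order, so the result records a ranking and gives no reason for it.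

Still open, going by these compounds, is how a ring at this position behaves when it carries a nitrile, a methoxy group or a trifluoromethyl group instead of halogens. Also open, on these data alone, is what happens when an amine takes the place of the ring on the sulfonyl sulfur, and whether the order seen here would hold with such groups.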